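A methyl on an aromatic oxygen: what to expect

The compounds below may be only part of what the source reports. "The series", "measured", "known", "first", "only" and "open" are said of these compounds alone.

Compound 1 `COc1ccc(/C=C/C(=O)Nc2nc3ccc(Cl)cc3s2)cc1`: 259 umol/kg
Compound 2 `O=C(/C=C/c1ccc(O)cc1)Nc1nc2ccc(Cl)cc2s1`: 322 umol/kg
Compound 3 `CC(=O)N1N=C(Nc2nc3ccc(Cl)cc3s2)CC1c1ccc(O)cc1`: 106 umol/kg

In a functional assay on the whole organism (Hindlimb, strain albino) with Mus musculus as the target, in the maximal electroshock model, with a stated time of 0.5 h (a lower number here means that less compound is needed, a higher number that more compound is needed for the effect), compound 2 gives 322 umol/kg and compound 1 gives 259 umol/kg. The two differ only by methyl in place of hydrogen on an oxygen on an aromatic ring, and the step is a 1.2-fold lower number from compound 2 to compound 1 (0.09 log units; within the scatter). Compound 3 carries a different core; how the cores of compound 2 and compound 3 differ is not broken down here. In this assay compound 3 gives 106 umol/kg, the lowest of the three numbers, and its gaps to compound 1 and to compound 2 both lie beyond the scatter.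

Compound 4 `COc1ccc(C2CC(Nc3nc4ccc(Cl)cc4s3)=NN2C(C)=O)cc1` has not yet been measured. Going by the values given here, it differs from compound 3 by methyl in place of hydrogen on an oxygen on an aromatic ring, the same change as the one from compound 2 to compound 1. That earlier step stayed within the scatter, so a similarly small movement is the natural expectation here. Compound 4 is therefore expected to show a step of about a 1.1-fold lower number from compound 3 to compound 4 (0.05 log units; within the scatter) in this assay. For compound 4 the estimate is 95 umol/kg, with a likely range from 45 umol/kg to 200 umol/kg. With one earlier example only, and that one on a different core, the expectation rests on little.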

Compound 4, dose for half-maximal effect: 93.3 umol/kg
Beside the measured number, compound 4's estimate is 1.0-fold (0.01 log units) above it, and the stated range covers the measured number.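

In this assay, hydroxy gives way to methoxy on the core of compound 3 with a 1.1-fold lower number from compound 3 to compound 4 (0.06 log units; within the scatter) and thus no movement that can be told from the usual scatter. Set beside the earlier case, the two steps agree: the same change on two cores in this assay, a 1.2-fold lower number (0.09 log units; within the scatter) from compound 2 to compound 1 and a 1.1-fold lower number (0.06 log units; within the scatter) from compound 3 to compound 4, 1.1-fold (0.04 log units) apart, within the scatter of two such steps. This shows that, on these two cores, the 4-hydroxyphenyl and 4-methoxyphenyl forms cannot be told apart in this read-out, but it does not show that the same would hold on any third core, and it gives no reason why the change is so quiet.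

The compounds shown carry only a hydrogen or a methyl on this oxygen, so it remains open what a longer chain there, such as ethyl or propyl, or an amine in place of the hydroxy or methoxy would do to the dose needed. Going by these compounds alone, with only two matched pairs at hand, the size of the step on further cores also remains open.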